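A few compounds are considered here, and "the series" means these few. Any claim that something is new, unique, unknown or untested is made for them only; others in the source may bear on it.

Working notes on the series. In an ADME assay on the whole organism (plasma, strain 129/SvEvBrd x C57BL/6) for pharmacokinetics, with Mus musculus as the target, at a dose of 10 mg/kg by the oral route (a higher number here means more compound in the circulation at the dose given, a lower number less compound in the circulation), compound 1 (`CC(=O)c1nc([C@@H](O)[C@H](O)[C@H](O)CO)c(-c2ccccc2)[nH]1`) gives 3520 ng.h/mL and compound 2 (`CC(F)(F)c1nc([C@@H](O)[C@H](O)[C@H](O)CO)c[nH]1`) gives 1190 ng.h/mL as the lower of the two numbers, a gap beyond the usual scatter. Compound 3 (`Cn1cnc(-c2nc([C@@H](O)[C@H](O)[C@H](O)CO)c[nH]2)c1`) is not yet measured and differs from compound 2 as follows: 1-methyl-1H-imidazol-4-yl in place of 1,1-difluoroethyl on an aromatic carbon. Going by the values given here, no measured step covers this change, so no shift beyond the scatter is expected. The expected step is a 1.2-fold lower number from compound 2 to compound 3 (0.08 log units; within the scatter) (an estimate with wide uncertainty). The estimate for compound 3 is 1000 ng.h/mL within an expected range of 250 ng.h/mL to 4000 ng.h/mL in this assay for now.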

Compound 3, area under the concentration-time curve: 698 ng.h/mL
Compound 3: middle estimate off by 1.4-fold (0.16 log units), on the high side, and the stated range covers the measured number.
By their numbers in this assay, from the lowest: compounds 3 and 2 (each within the scatter of the next); then compound 1.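

At the aromatic carbon between two ring nitrogen atoms, 1-methyl-1H-imidazol-4-yl in place of 1,1-difluoroethyl gives a 1.7-fold lower number from compound 2 to compound 3 (0.23 log units; within the scatter) in this assay. This position therefore carries an aromatic ring or an open group with no shift beyond the scatter for this pair. No measurement bearing on the reason for this step is available.

On these data alone, whether an amine, a carboxylic acid or a longer chain on this carbon would stay within the scatter remains open. Compound 1 differs from both compounds in more than one place, so its number cannot be assigned to any single group.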